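The source may report more compounds than this note shows. Statements on the series, on what has been measured and on what is new or still open speak of the compounds shown alone.

Going by the values given here, compound 3 `Nc1ccc2cc(NC(=O)CCc3ccc(C(F)(F)F)cc3)ccc2n1` gives 720 nM in a functional assay on HEK293 cells for activation of melanin-concentrating hormone receptor 1 (Rattus norvegicus), read by inositol phosphate accumulation (on this read-out lower numbers stand for an effect already at smaller amounts and higher numbers for an effect only at larger amounts of compound), the highest of the three numbers measured so far; compound 2 `O=C(CCc1ccc(C(F)(F)F)cc1)Nc1ccc2nc(N3CC4CC3CN4)ccc2c1` gives 490 nM and compound 1 `O=C(CCc1ccc(C(F)(F)F)cc1)Nc1ccc2nc(N3CCC(NS(=O)(=O)O)C3)ccc2c1` gives 50 nM. Compound 4 `O=C(CCc1ccc(C(F)(F)F)cc1)Nc1ccc2nc(N3CCCCC3)ccc2c1` differs from compound 3 by piperidin-1-yl in place of amino on an aromatic carbon. Among the compounds with values here, two measured steps bear on this change, since both arrive at the amino compound from a cyclic amine at the same position. The large step of a 14-fold higher number from compound 1 to compound 3 (1.16 log units; beyond the scatter) lies beyond the scatter, whereas the step of a 1.5-fold higher number from compound 2 to compound 3 (0.17 log units; within the scatter) lies within it. Running the change the other way, the piperidin-1-yl of compound 4 is expected to land between these two precedents, giving a lower number by a 3.6-fold lower number from compound 3 to compound 4 (0.56 log units; beyond the scatter). Compound 4 is therefore estimated at 200 nM, with a range from 60 nM to 700 nM.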

Compound 4, half-maximal effective concentration: 110 nM
Estimate against measurement, compound 4: 1.8-fold (0.26 log units) above, and the stated range covers the measured number.
By their numbers in this assay, from the lowest: compound 1; then compound 4; then compounds 2 and 3 (each within the scatter of the next).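

In this assay, a bare piperidin-1-yl on this aromatic carbon next to the ring nitrogen is enough for a clear shift from amino: a 6.5-fold lower number from compound 3 to compound 4 (0.82 log units; beyond the scatter). A second nitrogen and a bridged ring are not needed for a low number, as a 4.5-fold lower number from compound 2 to compound 4 (0.65 log units; beyond the scatter) shows. The sulfoamino-bearing pyrrolidine keeps a smaller edge, seen in a 2.2-fold higher number from compound 1 to compound 4 (0.34 log units; beyond the scatter).

Open, on these data alone, is whether morpholin-4-yl, or a piperidine bearing a carboxylic acid, would take the number lower. No evidence on hand accounts for any of these steps.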